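From a Chlorinated Ring to a Difluorinated One

The source may report more compounds than this note shows. Statements on the series, on what has been measured and on what is new or still open speak of the compounds shown alone.

Of the compounds shown here, three built on one shared core have been tested in a functional assay for agonist activity at G protein-coupled receptor 88 (Homo sapiens), read by HTRF and cAMP accumulation; a higher number here means that more compound is needed for the effect, a lower number that less compound is needed. Compound 1 `CC(C)CCCN(C(=O)[C@@H]1C[C@H]1c1ccccc1)c1ccc(-c2ccccc2)cc1` reaches only a limit there, giving > 100 nM. Compound 2 `CCC(CC)C(N)CCN(C(=O)[C@@H]1C[C@H]1c1ccccc1)c1ccc(-c2ccccc2)cc1` gives 2 nM in this assay. Among the compounds with values here, the single measured step, an at least 50-fold lower number from compound 1 to compound 2 (1.69 log units; beyond the scatter), concerns the chain on the amide-type nitrogen and not the aromatic ring at the other end of the molecule. Compound 3 `CC[C@H](C)[C@H](N)CN(C(=O)[C@@H]1C[C@H]1c1ccccc1Cl)c1ccc(-c2ccccc2)cc1` again reaches only a limit, giving > 25000 nM in this assay. That result sits at the limit of > 25000 nM in this assay, at which 1 of the 3 values shown sits. Compound 1 sits at the limit of > 100 nM in this assay, at which 1 of the 3 values shown sits. Compound 4 `CC[C@H](C)[C@H](N)CN(C(=O)[C@@H]1C[C@H]1c1cc(F)cc(F)c1)c1ccc(-c2ccccc2)cc1` differs from compound 3 in one place: 3,5-difluorophenyl in place of 2-chlorophenyl on a saturated ring carbon. No measured step touches this ring, so nothing shown gives the direction or the size of the change to be expected. The step of an at least 5.0-fold lower number from compound 3 to compound 4 (0.69 log units; beyond the scatter) is therefore an estimate with little support, and since compound 3 shows only a limit, the step itself cannot be fixed. Compound 4 is expected to give around 5000 nM in this assay, with a likely range from 200 nM to 25000 nM.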

Compound 4, half-maximal effective concentration: 960 nM
Beside the measured number, compound 4's estimate is 5.2-fold (0.72 log units) above it, within the range that was stated.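

Within the data shown here, the phenyl ring on the three-membered ring, which no earlier step touched, clearly matters in this assay: 3,5-difluorophenyl in place of 2-chlorophenyl gives an at least 26-fold lower number from compound 3 to compound 4 (1.41 log units; beyond the scatter), a large change beyond the scatter. This step marks only the least the change can be, as compound 3 gives a limit of the assay and not a number: the limit of > 25000 nM in this assay, at which 1 of the 4 values shown sits. Both groups count no hydrogen-bond donors, no hydrogen-bond acceptors and no net charge, so the step follows a change in the halogens on the phenyl ring, with those counts unchanged.

The compounds shown cannot separate losing the chlorine from gaining the two fluorines, which a plain phenyl or a 3-fluorophenyl on the chain of compound 3 would help to do. They also leave open whether 3,5-difluorophenyl would have a similar effect on the chain of compound 2.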